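The source may hold more compounds than are shown below. What is called first, only, known or untested is meant among the compounds shown, and "the series" means these compounds.

Within the data shown here, compound 2 `CC1=C(SCCC(=O)OC(C[Se]c2ccccc2)C(=O)NCCCCCC(=O)OCc2ccccc2)C(=O)c2ccccc2C1=O` stands at the higher of the two numbers so far in an ADME assay on PHF cells (Homo sapiens) for cytotoxicity, read by MTT assay, with a stated time of 24 h (a lower number here means a stronger inhibitor, a higher number a weaker inhibitor), giving 50000 nM. Among the measured compounds shown here, its only neighbour is compound 1 `CC1=C([Se]CC(OC(=O)[C@@H](CO)NC(=O)OC(C)(C)C)C(=O)NC(C)(C)C)C(=O)c2ccccc2C1=O`, and in this assay compound 1 gives 7000 nM, a gap beyond the scatter. Compound 3 `CC1=C(SCCC(=O)OC(CC[Se]c2ccccc2)C(=O)NCCCCCC(=O)OCc2ccccc2)C(=O)c2ccccc2C1=O` has not yet been measured in this assay; it differs from compound 2 by a group of 8 heavy atoms (7 carbon, 1 selenium; one six-membered aromatic ring of carbon only) in place of a group of 7 heavy atoms (6 carbon, 1 selenium; one six-membered aromatic ring of carbon only), on a saturated chain carbon, two bonds along the chain from a carbonyl carbon and an oxygen next to a carbonyl group. For the measured compounds named here, no pair of measured compounds shares a step of this kind, so the expectation rests on the change alone. The expected step of no change at the digits printed from compound 2 to compound 3 (within the scatter) is small, in neither direction beyond the scatter. Compound 3 is therefore estimated at 50000 nM, within a range from 20000 nM to 125000 nM.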

Compound 3, half-maximal inhibitory concentration: 21000 nM
The estimate for compound 3 lay 2.4-fold (0.38 log units) above the measured number; measured number inside the range.
By their numbers in this assay, from the lowest: compound 1; then compound 3; then compound 2.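

In this assay, a group of 8 heavy atoms in place of a group of 7 heavy atoms, on a saturated chain carbon, gives a 2.4-fold lower number from compound 2 to compound 3 (0.38 log units; beyond the scatter) and is modest. This shows that the number responds to a change at this position, even though the selenium and the six-membered aromatic ring are present on both sides of the step. No supporting data bear on why this happens. On these data alone, the effect of a longer chain at this carbon remains open, as does that of an amine in place of this group. A single step cannot establish a trend.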